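A Chloro Group Added to the Phenyl of Compound 3

A few compounds are considered here, and "the series" means these few. Any claim that something is new, unique, unknown or untested is made for them only; others in the source may bear on it.

Compound 1 `N#Cc1c(Nc2ccc(Cl)cc2)nc(SCc2cn(Cc3ccccc3Cl)nn2)nc1-c1ccccc1` gives 6520 nM in a functional assay on MCF7 cells (Homo sapiens) for inhibition, read by MTT assay, with a stated time of 72 h; a lower number here means a stronger inhibitor, a higher number a weaker inhibitor.
Compound 2 `Cc1ccc(Nc2nc(SCc3cn(Cc4ccc(Cl)cc4)nn3)nc(-c3ccccc3)c2C#N)cc1` reaches only a limit of this assay, > 64000 nM, not a number.
Compound 3 `Cc1ccc(Nc2nc(SCc3cn(Cc4ccccc4Cl)nn3)nc(-c3ccccc3)c2C#N)cc1` gives 9420 nM.

All three share one core. Compound 3 holds the highest of the two numbers, but its nearest neighbour, compound 1, sits within the scatter of it, as a 1.4-fold higher number from compound 1 to compound 3 (0.16 log units; within the scatter) shows. Within the data shown here, the one step beyond the scatter, an at least 6.7-fold lower number from compound 2 to compound 3 (0.83 log units; beyond the scatter), moved a chloro group on a different ring. Compound 4 `Cc1ccc(Nc2nc(SCc3cn(Cc4ccccc4Cl)nn3)nc(-c3ccc(Cl)cc3)c2C#N)cc1` is compound 3 with chloro in place of hydrogen on an aromatic carbon. Among the measured compounds shown here, no measured step touches that phenyl ring, so there is no direct guide. A change within the scatter is expected, a 1.0-fold lower number from compound 3 to compound 4 (0.02 log units; within the scatter). Compound 4 is therefore estimated at 9000 nM, with a range from 3000 nM to 30000 nM.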

Compound 4, half-maximal inhibitory concentration: 14700 nM
The estimate for compound 4 lay 1.6-fold (0.21 log units) below the measured number; low and high end bracket the measured number.
By their numbers in this assay, from the lowest: compounds 1, 3 and 4 (each within the scatter of the next, the first and the last beyond it). At a limit, above all of these: compound 2.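

In this assay, among these compounds, the change from phenyl to 4-chlorophenyl, on a ring that no earlier step touched, gives a 1.6-fold higher number from compound 3 to compound 4 (0.19 log units; within the scatter) and so cannot be told apart from hydrogen at this place. This position therefore accepts a chloro group without a shift that stands clear of the scatter. Nothing measured here bears on the reason for this step.

From the compounds shown here alone, whether a different group at this place, such as a methoxy group, an amine or a carboxylic acid, would move the number beyond the scatter stays open. So does whether chloro here would behave alike alongside the other groups of compound 1 or compound 2.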